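Sulfonamide heteroaryl variation on a shared thiourea core

A few compounds are considered here, and "the series" means these few. Any claim that something is new, unique, unknown or untested is made for them only; others in the source may bear on it.

Three compounds sharing one core differ only in the group on the sulfonamide nitrogen. Compound 1 `Cc1noc(NS(=O)(=O)c2ccc(N/C(S)=N\c3ccnc4cc(C(F)(F)F)ccc34)cc2)c1C` gives 67100 nM in a functional assay on LoVo cells (Homo sapiens) for antiproliferative activity, read by sulforhodamine B assay, with a stated time of 48 h; on this read-out lower numbers stand for stronger inhibition and higher numbers for weaker inhibition; compound 2 `O=S(=O)(Nc1ccccn1)c1ccc(N/C(S)=N\c2ccnc3cc(C(F)(F)F)ccc23)cc1` gives 87500 nM; compound 3 `Cc1ccnc(NS(=O)(=O)c2ccc(N/C(S)=N\c3ccnc4cc(C(F)(F)F)ccc34)cc2)n1` gives 31000 nM, the lowest number of the three, with a 2.2-fold lower number from compound 1 to compound 3 (0.34 log units; beyond the scatter) and a 2.8-fold lower number from compound 2 to compound 3 (0.45 log units; beyond the scatter) both beyond the scatter, while a 1.3-fold higher number from compound 1 to compound 2 (0.12 log units; within the scatter) is not.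

Compound 4 `COc1ncnc(NS(=O)(=O)c2ccc(N/C(S)=N\c3ccnc4cc(C(F)(F)F)ccc34)cc2)c1OC` is not yet measured. The change from compound 3 is 5,6-dimethoxypyrimidin-4-yl in place of 4-methylpyrimidin-2-yl on a sulfonamide nitrogen. Among the compounds with values here, no measured step swaps one pyrimidinyl for another; the steps that bear on it only show that exchanging the heteroaryl on this nitrogen moved this assay by modest amounts in either direction, with compound 3 at the low end. Within the data shown here, an added pair of methoxy groups and a changed attachment point give no precedent here, so a step of modest size, more likely upward than downward from the lowest number of the set, is expected: a 1.5-fold higher number from compound 3 to compound 4 (0.16 log units; within the scatter). Compound 4 is therefore estimated at 45000 nM, within 15000 nM to 130000 nM.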

Compound 4, half-maximal inhibitory concentration: 28400 nM
Compound 4: middle estimate off by 1.6-fold (0.20 log units), on the high side, within the range that was stated.
By their numbers in this assay, from the lowest: compounds 4 and 3 (each within the scatter of the next); then compounds 1 and 2 (each within the scatter of the next).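

In this assay, the 5,6-dimethoxypyrimidin-4-yl group replaces 4-methylpyrimidin-2-yl on the sulfonamide nitrogen with a 1.1-fold lower number from compound 3 to compound 4 (0.04 log units; within the scatter), so on this evidence the two pyrimidinyl groups cannot be told apart, despite the two methoxy groups and the changed attachment point. The low end of the set is now held by two pyrimidinyl compounds, since a 3.1-fold lower number from compound 2 to compound 4 (0.49 log units; beyond the scatter) and a 2.4-fold lower number from compound 1 to compound 4 (0.37 log units; beyond the scatter) both lie beyond the scatter, as do the matching steps to compound 3; none of the four compounds goes against this. Nothing available bears on why the pyrimidinyl groups sit together.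

Compound 4 changes the substituents and the attachment point at once, so their separate contributions remain unresolved. Also open, as far as these compounds go, is how a plain phenyl group, a 5-methoxypyrimidin-4-yl group or an acetyl group on this nitrogen would compare.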